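The source may hold more compounds than are shown below. What is called first, only, known or untested is meant among the compounds shown, and "the series" means these compounds.

Measured so far in a functional assay on the whole organism for agonist activity, with Mus musculus as the target; a lower number here means that less compound is needed, a higher number that more compound is needed for the effect:
- compound 1 `CC(C#CCn1ccnc1)N1CCCC1=O`: > 100 mg/kg
- compound 2 `CN1CCN(CC#CCn2ccnc2)C1=O`: 1.4 mg/kg
- compound 3 `CC(C#CCN1CCCC1)N1CCN(C)C1=O`: > 30 mg/kg

Of these three results, only compound 2 has a measured number. The result for compound 1 is a limit. Compound 3 also stands at a limit, > 30 mg/kg, so its place on the scale is bounded but not fixed.

Compound 4 `CC(C#CCn1ccnc1)N1CCN(C)C1=O`, not yet measured, has 1H-imidazol-1-yl in place of pyrrolidin-1-yl on a saturated chain carbon bound to a triple-bonded carbon.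

Going by the values given here, no measured pair isolates this exchange, so the expectation in this assay rests on indirect evidence. In its favour stands compound 2, which carries 1H-imidazol-1-yl and gives 1.4 mg/kg. Compound 1 carries the same group and goes against that reading, with only a limit of > 100 mg/kg. A moderate move toward less compound needed is therefore expected, though another limit instead of a number would be no surprise. The expected change is an at least 2.5-fold lower number from compound 3 to compound 4 (0.39 log units; beyond the scatter).

For compound 4, the estimated value is 12 mg/kg, with an expected range from 2 mg/kg to 80 mg/kg.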

Compound 4, dose for half-maximal effect: > 100 mg/kg
Compound 4 gave a limit, no number (the forecaster's own chance of this, stated with the estimate: 45%); middle value at least 8.3-fold (0.92 log units) from the limit.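

In this assay, methyl in place of hydrogen on a saturated chain carbon bound to an amide-type nitrogen in a ring and a triple-bonded carbon gives an at least 71-fold higher number from compound 2 to compound 4 (1.85 log units; beyond the scatter), the first step among these compounds that can be read. This is a large change from a single added methyl with 1H-imidazol-1-yl held in place, and it leaves compound 2 as the only compound shown with a measured number rather than a limit. The exchange of pyrrolidin-1-yl for 1H-imidazol-1-yl between compound 3 and compound 4 cannot be read, since both results are limits and the one for compound 4 is this: the limit of > 100 mg/kg in this assay, at which 2 of the 4 values shown sit.

The compounds shown leave open how pyrrolidin-1-yl behaves when the chain carbon carries hydrogen instead of methyl, so the effect of that exchange on the unbranched chain remains unknown. They also leave open whether only methyl has this effect at that chain carbon or whether a fluorine atom, an ethyl group or a cyclopropyl ring there would give a measurable dose.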